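Oxime Double-Bond Geometry and Acid Dissociation

A few compounds are considered here, and "the series" means these few. Any claim that something is new, unique, unknown or untested is made for them only; others in the source may bear on it.

In a physicochemical assay for acid dissociation, compound 1 `O/N=C/c1nc(-c2cccs2)no1` gives 8.03. Compound 2 `Cc1noc(/C=N/O)n1` gives 8.11. Compound 3 `CC(C)(C)c1noc(/C=N/O)n1` gives 7.91.

Compound 2 stands among three numbers that all lie within the scatter of one another, so none of the three can be told apart on this read-out. Compound 4 `Cc1noc(/C=N\O)n1` differs from compound 2 as follows: the two compounds have the same atoms and bonds and differ only in configuration as drawn: 1 of 1 stereo elements differ; a double bond is drawn E in compound 2 and Z in compound 4. For the measured compounds named here, the only measured step, a number 0.20 log units lower from compound 2 to compound 3 (within the scatter), swaps one group for another and does not touch the double bond, so no measured step bears directly on this change. Going by the values given here, with every number so far sitting close together, no step beyond the scatter is expected in this assay. Compound 4 is therefore estimated at 8.05, within 7.55 to 8.55, which means an expected step of a number 0.06 log units lower from compound 2 to compound 4 (within the scatter).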

Compound 4, acid dissociation constant: 8.6
Estimate against measurement, compound 4: 0.55 log units below; the whole stated range lies below it.
By their numbers in this assay, from the lowest: compounds 3, 1 and 2 (each within the scatter of the next); then compound 4.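

In this assay, the geometry of the double bond is the first change shown that moves the number beyond the scatter: a number 0.49 log units higher from compound 2 to compound 4 (beyond the scatter). For the compounds shown here, the swap of methyl for tert-butyl stayed within the scatter, so the earlier compounds gave no sign that this position could shift the read-out. The step can be assigned to geometry alone because of how the pair is related: the fact that compounds 2 and 4 differ only in the configuration as drawn.

On these data alone, whether the same change from E to Z gives a similar step with tert-butyl, or with an amine or a carboxylic acid in place of methyl, stays open.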